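Aminothiophene ketones: thiophene halogen swap on the carbonyl

The compounds below may be only part of what the source reports. "The series", "measured", "known", "first", "only" and "open" are said of these compounds alone.

Measured compounds in an assay for inhibition of Maternal embryonic leucine zipper kinase (Homo sapiens), read by ADP-Glo, with a stated time of 0.5 h; on this read-out lower numbers stand for stronger inhibition and higher numbers for weaker inhibition:
- compound 1 `COc1ccc(C(=O)c2sc(NC(C)C)c(C#N)c2N)cc1OC`: 1770 nM
- compound 2 `CC(C)Nc1sc(C(=O)c2ccco2)c(N)c1C#N`: 1350 nM
- compound 3 `CC(C)Nc1sc(C(=O)c2ccc(Cl)s2)c(N)c1C#N`: 192 nM

Compound 3 stands lowest of the three numbers in this assay. Its nearest neighbour is compound 2, and compound 1 lies furthest away; both gaps are beyond the scatter, so compound 3 is the strongest inhibitor of the set so far.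

The next compound, compound 4 `CC(C)Nc1sc(C(=O)c2cc(Br)cs2)c(N)c1C#N`, keeps the shared core of compound 3 and alters only the ring on the carbonyl: 4-bromothiophen-2-yl in place of 5-chlorothiophen-2-yl on a carbonyl carbon.

Going by the values given here, the one measured step that touches this position is a 7.0-fold lower number from compound 2 to compound 3 (0.85 log units; beyond the scatter), where the furan-2-yl gave way to 5-chlorothiophen-2-yl. Among the compounds with values here, no measured pair compares two halothiophenes with one another, so the size of the present step is not anchored by data; the only guidance is that the halothiophene class already sits well below furan. A step of modest size in either direction, or none beyond the scatter, is therefore plausible, with somewhat more weight on a weaker number since the best-performing substituent is being replaced.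

For compound 4 in this assay the expected value is 350 nM, within 120 nM to 1000 nM, which corresponds to an estimated step of a 1.8-fold higher number from compound 3 to compound 4 (0.26 log units; within the scatter).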

Compound 4, half-maximal inhibitory concentration: 599 nM
The estimate for compound 4 lay 1.7-fold (0.23 log units) below the measured number, and the stated range covers the measured number.
By their numbers in this assay, from the lowest: compound 3; then compound 4; then compounds 2 and 1 (each within the scatter of the next).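

Within the halothiophene ketones, the ring on the carbonyl carbon is not interchangeable in this assay: 4-bromothiophen-2-yl in place of 5-chlorothiophen-2-yl gives a clear loss (a 3.1-fold higher number from compound 3 to compound 4 (0.49 log units; beyond the scatter)), although the two groups match in heavy-atom, donor and acceptor counts. The advantage over furan-2-yl shrinks but does not vanish (a 2.3-fold lower number from compound 2 to compound 4 (0.35 log units; beyond the scatter)), so compound 3 and compound 4 both stand below compound 2, and this advantage now rests on two halothiophenes rather than one. This swap changes the halogen and its place on the thiophene in a single step, so the loss cannot be assigned to either change alone, and no measurement on hand offers an explanation for it.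

The matched pair that would separate these two changes is open: 5-bromothiophen-2-yl or 4-chlorothiophen-2-yl on the same carbonyl carbon, set against compound 3 and compound 4. Also open, going by these compounds, is how much of the advantage over furan-2-yl needs a halogen at all, a question that unsubstituted thiophen-2-yl or 5-methylthiophen-2-yl at this position would address.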